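The compounds below may be only part of what the source reports. "The series", "measured", "known", "first", "only" and "open" are said of these compounds alone.

Compound 1 `C=CCNC(=S)NCCCCn1nc(-c2ccccc2)ccc1=O` and compound 2 `N#CNC(=N)NCCCCn1nc(-c2ccccc2)ccc1=O` share one core and differ only at an amine nitrogen. In a functional assay on the whole organism (stomach) with Rattus norvegicus as the target (on this read-out higher numbers stand for an effect only at larger amounts of compound and lower numbers for an effect already at smaller amounts), compound 1 reached only a limit of the assay, > 100 mg/kg. In this assay, going by the values given here, compound 2 gave 77.2 mg/kg, the only plain number among the values shown. That step, an at least 1.2-fold lower number from compound 1 to compound 2 (0.11 log units; that floor lies within the scatter), rests on the limit (the limit of > 100 mg/kg in this assay, at which 1 of the 2 values shown sits). Compound 3 `C/N=C(\S)NCCCn1nc(-c2ccccc2)ccc1=O` differs from compound 2 by a group of 5 heavy atoms (2 carbon, 2 nitrogen, 1 sulfur; no ring) in place of a group of 7 heavy atoms (3 carbon, 4 nitrogen; no ring), on a saturated chain carbon, three bonds along the chain from an aromatic nitrogen. Among the compounds with values here, only the step from compound 1 to compound 2 bears on this change, and it stays within the scatter, so no step beyond the scatter is expected in this assay. Compound 3 is therefore estimated at 90 mg/kg, between 40 mg/kg and 200 mg/kg, an expected step of a 1.2-fold higher number from compound 2 to compound 3 (0.07 log units; within the scatter).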

Compound 3, dose for half-maximal effect: > 100 mg/kg
Compound 3: no number, only a limit; the forecaster's own chance of this, stated with the estimate: 40%; middle value at least 1.1-fold (0.04 log units) away from the limit.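

In this assay compound 3 gives only a limit of the assay, so the group of 5 heavy atoms with sulfur, on a saturated chain carbon, gains no plain number. The change to it yields only a floor, an at least 1.2-fold higher number from compound 2 to compound 3 (0.11 log units; that floor lies within the scatter), which neither shows nor excludes a real loss. The step between compound 1 and compound 3 cannot be read, and the data pile up at one ceiling: the limit of > 100 mg/kg in this assay, at which 2 of the 3 values shown sit.

As far as these compounds go, how far compound 3 lies past its limit stays open. So does whether an amine or a carboxylic acid at this place would give a plain number.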